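Compound 3: Cyclohexenyl Replaced by 4-Methylphenyl

A few compounds are considered here, and "the series" means these few. Any claim that something is new, unique, unknown or untested is made for them only; others in the source may bear on it.

In a functional assay for agonist activity at G protein-coupled receptor 88 (Homo sapiens), read by HTRF and cAMP accumulation (on this read-out lower numbers stand for an effect already at smaller amounts and higher numbers for an effect only at larger amounts of compound), compound 1 `CC(C)C[C@H](N)CN(C(=O)[C@@H]1C[C@H]1c1ccccc1)c1ccc(-c2cccs2)cc1` gives 1500 nM.
In this assay compound 2 `CC(C)C[C@H](N)CN(C(=O)[C@@H]1C[C@H]1c1ccccc1)c1ccc(C2=CCCCC2)cc1` gives 1200 nM.

Compound 2 stands at the lowest of the two numbers, yet the step of a 1.3-fold lower number from compound 1 to compound 2 (0.10 log units; within the scatter) lies within the scatter, so the two compounds cannot be told apart. Compound 3 `Cc1ccc(-c2ccc(N(C[C@@H](N)CC(C)C)C(=O)[C@@H]3C[C@H]3c3ccccc3)cc2)cc1` differs from compound 2 by 4-methylphenyl in place of cyclohex-1-en-1-yl on an aromatic carbon. Among the measured compounds shown here, the only measured step at that aromatic carbon, a 1.3-fold lower number from compound 1 to compound 2 (0.10 log units; within the scatter), stayed within the scatter, so the expectation for compound 3 is a 1.1-fold higher number from compound 2 to compound 3 (0.03 log units; within the scatter), no step beyond the scatter. In this assay compound 3 is therefore estimated at 1300 nM, with a range from 500 nM to 3500 nM.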

Compound 3, half-maximal effective concentration: 360 nM
Compound 3: the middle estimate sits 3.6-fold (0.56 log units) above what was measured; measured number below the stated range.
By their numbers in this assay, from the lowest: compound 3; then compounds 2 and 1 (each within the scatter of the next).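

In this assay the group on this aromatic carbon now proves to matter, with a 3.3-fold lower number from compound 2 to compound 3 (0.52 log units; beyond the scatter) and a 4.2-fold lower number from compound 1 to compound 3 (0.62 log units; beyond the scatter) both beyond the scatter, unlike the earlier exchange of thiophen-2-yl for cyclohex-1-en-1-yl. Of the three groups, only 4-methylphenyl sets its compound apart, though both steps remain modest. No evidence is available to explain this difference.

The compounds shown leave open whether the aromatic ring or its methyl group carries the step. They also leave open how an unsubstituted phenyl, a methoxy group or an amine on that ring would compare.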